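The source may report more compounds than this note shows. Statements on the series, on what has been measured and on what is new or still open speak of the compounds shown alone.

Measured compounds:
compound 1, `CC(C)(C)N(NC(=O)c1ccccc1I)C(=O)c1ccccc1Cl`, in an assay on cells for agonist activity at ecdysone receptor (Bombyx mori), read by a luciferase reporter, with a stated time of 24 h (a higher number here means that more compound is needed for the effect, a lower number that less compound is needed), compound 1 gives 1290 nM
compound 2, `CCc1ccc(C(=O)NN(C(=O)c2ccccc2Cl)C(C)(C)C)cc1`, in this assay compound 2 gives 5.75 nM

Among the compounds with values here, compound 2 stands lowest of the two numbers in this assay; the single step between them, a 220-fold lower number from compound 1 to compound 2 (2.35 log units; beyond the scatter), sets compound 2 well apart from compound 1. That step concerns the carbonyl carbon that carries the 2-iodophenyl or 4-ethylphenyl group.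

Compound 3, `CCc1ccc(C(=O)NN(C(=O)C2CCCCC2)C(C)(C)C)cc1`, differs from compound 2 by cyclohexyl in place of 2-chlorophenyl on a carbonyl carbon. Within the data shown here, no measured step touches this carbonyl carbon: both measured compounds carry 2-chlorophenyl there, and the only step known, a 220-fold lower number from compound 1 to compound 2 (2.35 log units; beyond the scatter), lies on the other carbonyl. The measurements therefore give no direct guide to what the exchange of an aromatic ring for a non-aromatic one at this place does. With that reservation, the expectation for compound 3 in this assay is a step to a higher number, beyond the scatter, of the size a 10-fold higher number from compound 2 to compound 3 (1.02 log units; beyond the scatter). The estimate for compound 3 is 60 nM, with a range from 8 nM to 500 nM.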

Compound 3, half-maximal effective concentration: 9330 nM
For compound 3 the middle estimate is 160-fold (2.19 log units) below the measured one; measured number above the stated range.
By their numbers in this assay, from the lowest: compound 2; then compound 1; then compound 3.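

Working notes on the series. Within the data shown here, the carbonyl carbon carrying 2-chlorophenyl, constant in the earlier compounds, proves highly sensitive in this assay: cyclohexyl in place of 2-chlorophenyl gives a 1600-fold higher number from compound 2 to compound 3 (3.21 log units; beyond the scatter). This large step arises although both groups hold a six-membered ring of carbon only, with the same counts of hydrogen-bond donors and acceptors and no net charge; the counted differences are the aromatic versus non-aromatic ring and the chlorine, and the two cannot be separated with these compounds. Together with a 220-fold lower number from compound 1 to compound 2 (2.35 log units; beyond the scatter), large steps are now seen at both carbonyl carbons, and no accompanying measurement speaks to the origin of the new step.

Still open, from the compounds shown here alone, is whether the aromatic ring alone carries the effect at this carbonyl carbon, a question that an unsubstituted phenyl group or a 2-methylphenyl group would address directly. Also open, going by these compounds, is how a cyclohexyl group bearing a chlorine, or a short open chain such as n-butyl, would behave here, and whether the size of the step holds with a group other than 4-ethylphenyl on the other carbonyl carbon.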